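Cyclohexyl for cyclopentyl on the amine of compound 1

This account rests on a few compounds, and the source may have more. Where it says the series, first, only, none or still open, it means among the compounds named here.

Measured so far, in a functional assay on CHO cells for antagonist activity at adenosine receptor A2b (Homo sapiens), read by 33P incorporation, with a stated time of 20 min; a higher number here means a weaker inhibitor, a lower number a stronger inhibitor:
compound 1, `Cn1c(-c2ccccc2)nc2c(NC3CCCC3)ncnc21`, gives 8510 nM
compound 2, `Cn1c(-c2ccc(O)cc2)nc2c(NC3CCCC3)ncnc21`, gives 17800 nM
compound 3, `Cn1c(-c2ccc(F)cc2)nc2c(NC3CCCC3)ncnc21`, gives > 30000 nM, which is a limit and not a number the limit of > 30000 nM in this assay, at which 1 of the 3 values shown sits.

Compound 1 holds the lowest of the two numbers shown; the nearest is compound 2, with a 2.1-fold higher number from compound 1 to compound 2 (0.32 log units; beyond the scatter). Compound 3 sits at the limit (the limit of > 30000 nM in this assay, at which 1 of the 3 values shown sits). Both measured steps from compound 1 change the aromatic ring carried by the shared core: an at least 3.5-fold higher number from compound 1 to compound 3 (0.54 log units; beyond the scatter), and between compound 2 and compound 3 an at least 1.6-fold higher number from compound 2 to compound 3 (0.22 log units; that floor lies within the scatter).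

Compound 4, `Cn1c(-c2ccccc2)nc2c(NC3CCCCC3)ncnc21`, differs from compound 1 elsewhere: cyclohexyl in place of cyclopentyl on a nitrogen on an aromatic ring. Within the data shown here, none of the measured steps touches the cyclopentyl on the nitrogen; all of them concern substituents on the aromatic ring, so they give no direct reading on this change. With nothing to push the number one way or the other, compound 4 is expected to stay within the scatter of compound 1, meaning a 1.0-fold lower number from compound 1 to compound 4 (0.00 log units; within the scatter). The estimate for compound 4 in this assay is therefore 8500 nM, with a range from 3000 nM to 25000 nM.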

Compound 4, inhibition constant: > 30000 nM
Compound 4 was reported as a limit (the forecaster's own chance of this, stated with the estimate: 15%); middle value at least 3.5-fold (0.54 log units) away from the limit.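

Among these compounds, the cyclopentylamino to cyclohexylamino change gives the first reading at this place on the nitrogen in this assay, and it is not silent: an at least 3.5-fold higher number from compound 1 to compound 4 (0.54 log units; beyond the scatter). The number of compound 1 therefore responds to the group on the amine as well as to the substituents on the aromatic ring carried by the shared core, and compound 1 remains the strongest of the four, with its steps to all the others printed as beyond the scatter. The value of compound 4, > 30000 nM, is a limit and not a number, so this step is a floor only: the limit of > 30000 nM in this assay, at which 2 of the 4 values shown sit.

Still open, as far as these compounds go, is whether a smaller ring or an open chain on this nitrogen, such as cyclobutyl or isopropyl, would give a lower number than cyclopentyl or a higher one. Also open, from the compounds shown here alone, is whether a hydroxy or an amine placed on the cyclopentyl ring would change the number of compound 1, and whether the hydroxy and fluoro steps on the aromatic ring carry over to the cyclohexylamino compounds.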